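A few compounds are considered here, and "the series" means these few. Any claim that something is new, unique, unknown or untested is made for them only; others in the source may bear on it.

In a functional assay on MOLT-4 cells (Homo sapiens) for cytotoxicity, read by MTT assay, with a stated time of 48 h (on this read-out higher numbers stand for weaker inhibition and lower numbers for stronger inhibition), three compounds have been measured:

Compound 1 `[O-][n+]1nc(NCCO)[n+]([O-])c2ccccc21` gives 2600 nM
Compound 2 `[O-][n+]1nc(NC2CC2)[n+]([O-])c2ccccc21` gives 1900 nM
Compound 3 `O=[N+]([O-])c1ccc(CNc2n[n+]([O-])c3ccccc3[n+]2[O-])cc1` gives 800 nM

Compound 2 holds the second highest of these three numbers, within the scatter of compound 1 and separated from compound 3 by more than the scatter. Compound 4 `C=CCNc1n[n+]([O-])c2ccccc2[n+]1[O-]` awaits measurement. It differs from compound 2 by one change (allyl in place of cyclopropyl on a nitrogen on an aromatic ring), with allyl in place of cyclopropyl on a nitrogen on an aromatic ring. Going by the values given here, the one measured step at that place (a 1.4-fold lower number from compound 1 to compound 2 (0.14 log units; within the scatter)) stayed within the scatter, so no step beyond the scatter is expected in this assay here. The estimate means a 1.1-fold lower number from compound 2 to compound 4 (0.05 log units; within the scatter) as the expected step. Compound 4 is expected at 1700 nM (estimated range 800 nM to 3600 nM).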

Compound 4, half-maximal inhibitory concentration: 3000 nM
Compound 4: the middle estimate sits 1.8-fold (0.25 log units) below what was measured, and the stated range covers the measured number.
By their numbers in this assay, from the lowest: compound 3; then compounds 2, 1 and 4 (each within the scatter of the next).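

In this assay, allyl in place of cyclopropyl on a nitrogen on an aromatic ring gives a 1.6-fold higher number from compound 2 to compound 4 (0.20 log units; within the scatter), and vinyl in place of hydroxymethyl on the saturated chain carbon gives a 1.2-fold higher number from compound 1 to compound 4 (0.06 log units; within the scatter). Both steps stay within the scatter, so compounds 1, 2 and 4 show that a ring, a double bond or a hydroxyl at this place leaves the number unresolved, while compound 3, at 800 nM, stands apart from compound 2. No measurement here accounts for these small steps.

As far as these compounds go, whether an amine or a longer chain at this nitrogen would stay within the scatter remains open.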